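The compounds below may be only part of what the source reports. "The series", "measured", "known", "first", "only" and "open" are said of these compounds alone.

The series shares one core, seen in compound 1 `O=C(/C=C\Nc1ccc(C(F)(F)F)cc1)c1cn(-c2ccccc2)nc1-c1ccccc1`, compound 2 `O=C(/C=C\Nc1ccc(O)cc1)c1cn(-c2ccccc2)nc1-c1ccccc1` and compound 3 `COc1ccc(N/C=C\C(=O)c2cn(-c3ccccc3)nc2-c2ccccc2)cc1`, and differs only in the group on the aniline ring. In a functional assay on U-87MG ATCC cells (Homo sapiens) for antiproliferative activity, read by MTT assay, with a stated time of 48 h (a higher number here means a weaker inhibitor, a lower number a stronger inhibitor), compound 1 gives a limit of the assay, > 50000 nM. Compound 2 gives 4290 nM in this assay. Compound 3 gives only a limit in this assay, > 50000 nM. The steps measured so far all sit on the aniline ring: an at least 11-fold lower number from compound 1 to compound 2 (1.06 log units; beyond the scatter); a step that the two limits leave unreadable from compound 1 to compound 3; an at least 11-fold higher number from compound 2 to compound 3 (1.06 log units; beyond the scatter). Compound 3 thus stands at the limit of > 50000 nM in this assay, at which 2 of the 3 values shown sit, with its distance to compound 2 readable and its distance to compound 1 not.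

Compound 4 `COc1ccc(N/C=C\C(=O)c2cn(-c3ccccc3)nc2-c2ccc(OC)cc2)cc1` keeps the methoxy on the aniline ring and differs from compound 3 in one place: methoxy in place of hydrogen on an aromatic carbon. Within the data shown here, none of the measured steps touches this second ring; the measured steps only show that the aniline substituent moves the number across a wide span. Among the measured compounds shown here, no step therefore reads directly onto this change. With compound 3 already at a limit, the expectation is that compound 4 stays there or near it, the estimated step being a step that the limit leaves unreadable from compound 3 to compound 4. Compound 4 is expected at 60000 nM, with a range from 15000 nM to 200000 nM, and most likely reported again as a limit.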

Compound 4, half-maximal inhibitory concentration: > 50000 nM
Compound 4 ended at the assay's limit (the forecaster's own chance of this, stated with the estimate: 75%); the middle value lies beyond the limit too.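

Compound 3 and compound 4 are both only limits in this assay, so no step between them can be read: the limit of > 50000 nM in this assay, at which 3 of the 4 values shown sit.

What phenyl to 4-methoxyphenyl does to the number stays open, as the compounds shown hold this change only in a pair at the limit and none pairs it with the hydroxy group of compound 2.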